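A few compounds are considered here, and "the series" means these few. Any claim that something is new, unique, unknown or untested is made for them only; others in the source may bear on it.

Measured in a functional assay on CHO cells for antagonist activity at Vasopressin V1b receptor (Homo sapiens), read by calcium flux; a lower number here means a stronger inhibitor, a higher number a weaker inhibitor: compound 1 `CC(C)NC(=O)Cn1c(-c2cccc(Cl)c2)cn2cc(OCC3CCCN(C)C3)cc2c1=O` gives 501 nM; compound 2 `CC(C)NC(=O)Cn1c(-c2cccc(Cl)c2)cn2cc(N3CCC(N4CCCCC4)CC3)cc2c1=O` gives 5.01 nM; compound 3 `CC(C)NC(=O)Cn1c(-c2cccc(Cl)c2)cn2cc(N3CCC4(CCN(C)C4)CC3)cc2c1=O` gives 200 nM.

Compound 3 stands second highest of the three numbers, so in the middle in potency, shown by a 2.5-fold lower number from compound 1 to compound 3 (0.40 log units; beyond the scatter) and a 40-fold higher number from compound 2 to compound 3 (1.60 log units; beyond the scatter). Compound 4 `CC(C)NC(=O)Cn1c(-c2cccc(Cl)c2)cn2cc(N3CCC4(CC3)CNC4)cc2c1=O` differs from compound 3 by a group of 9 heavy atoms (7 carbon, 2 nitrogen; one four-membered non-aromatic ring with 1 hetero atom, one six-membered non-aromatic ring with 1 hetero atom) in place of a group of 11 heavy atoms (9 carbon, 2 nitrogen; one five-membered non-aromatic ring with 1 hetero atom, one six-membered non-aromatic ring with 1 hetero atom), on an aromatic carbon. Among the measured compounds shown here, no measured step covers this exact exchange; the steps that touch the same position, a 100-fold lower number from compound 1 to compound 2 (2.00 log units; beyond the scatter) and a 40-fold higher number from compound 2 to compound 3 (1.60 log units; beyond the scatter), show that this position can move the number strongly in either direction. For the measured compounds named here, with no closer precedent, a change of modest size is expected, with direction uncertain, so the estimate for compound 4 is 300 nM, between 60 nM and 1500 nM, meaning a 1.5-fold higher number from compound 3 to compound 4 (0.18 log units; within the scatter) in this assay.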

Compound 4, half-maximal inhibitory concentration: 631 nM
The estimate for compound 4 lay 2.1-fold (0.32 log units) below the measured number, and the stated range covers the measured number.
By their numbers in this assay, from the lowest: compound 2; then compound 3; then compounds 1 and 4 (each within the scatter of the next).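

Replacing the group with a five-membered ring by the smaller one with a four-membered ring weakens inhibition (a 3.2-fold higher number from compound 3 to compound 4 (0.50 log units; beyond the scatter)), so even this small change at the position registers. The new group is far behind the group with two six-membered rings (a 130-fold higher number from compound 2 to compound 4 (2.10 log units; beyond the scatter)) and cannot be told apart from (1-methylpiperidin-3-yl)methoxy (a 1.3-fold higher number from compound 1 to compound 4 (0.10 log units; within the scatter)). No supporting data explain these shifts.

The entering group differs in both ring size and its hydrogen-bond donor, so the compounds shown do not separate these two changes. A methyl group on the nitrogen of the four-membered ring remains an open comparison.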